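Nitro on the styryl ring of a tetrahydropyran core

The source may hold more compounds than are shown below. What is called first, only, known or untested is meant among the compounds shown, and "the series" means these compounds.

Measured compounds:
compound 1 `O[C@@H](c1ccccc1)[C@H]1CO[C@H](c2ccccc2)[C@@H](C/C=C/c2ccccc2)C1` — 6060 nM
compound 2 `COc1ccc([C@H](O)[C@H]2CO[C@H](c3ccc(OC)c(OC)c3)[C@@H](C/C=C/c3ccc(OC)c(OC)c3)C2)cc1` — 46000 nM
compound 3 `COc1cccc(/C=C/C[C@H]2C[C@@H]([C@@H](O)c3ccc(OC)c(OC)c3)CO[C@@H]2c2ccc(OC)c(OC)c2)c1` — 14000 nM

In a functional assay on HeLa cells (Homo sapiens) for cytotoxicity, read by WST assay, with a stated time of 48 h (on this read-out lower numbers stand for stronger inhibition and higher numbers for weaker inhibition), compound 1 gives 6060 nM, the lowest of the three numbers. Its nearest neighbour is compound 3, whose value of 14000 nM lies beyond the scatter of compound 1, and the furthest is compound 2, whose value of 46000 nM lies further away still. No pair of these compounds differs in a single place, so no isolated step can be read from them.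

Compound 4 `O=[N+]([O-])c1ccccc1/C=C/C[C@H]1C[C@@H]([C@@H](O)c2ccccc2)CO[C@@H]1c1ccccc1` is related to compound 1 by one change: nitro in place of hydrogen on an aromatic carbon. For the measured compounds named here, only three compounds are known and none of them carries a nitro group, so the direction of this step cannot be read from what is measured. For compound 4 a step from compound 1 of a 1.2-fold lower number from compound 1 to compound 4 (0.08 log units; within the scatter) in this assay is expected, within the usual scatter. Compound 4 is therefore expected to give 5000 nM in this assay, with a range of 1800 nM to 15000 nM.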

Compound 4, half-maximal inhibitory concentration: 11800 nM
Compound 4: middle estimate off by 2.4-fold (0.37 log units), on the low side, within the range that was stated.
By their numbers in this assay, from the lowest: compounds 1, 4 and 3 (each within the scatter of the next, the first and the last beyond it); then compound 2.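

For the compounds shown here, compound 4 gives the first step in this set that can be read at a single place: on an aromatic carbon of the styryl ring, ortho to a large group, phenyl to 2-nitrophenyl gives a 1.9-fold higher number from compound 1 to compound 4 (0.29 log units; within the scatter) in this assay. On this read-out, the nitro group at this position therefore cannot be told apart from the hydrogen it replaces, even though it adds three heavy atoms to the core of compound 1. Nothing available explains the size of this step or shows what the nitro group does here. On these data alone, it remains open whether an amine or a carboxylic acid in the same place would give a step beyond the scatter. As far as these compounds go, it also remains open whether a nitro group on either of the other two aromatic rings of compound 1 would stay within the scatter.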